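Working notes on cytotoxicity: from compound 2 to compound 3

The source may hold more compounds than are shown below. What is called first, only, known or untested is meant among the compounds shown, and "the series" means these compounds.

Measured so far in an ADME assay on L02 cells (Homo sapiens) for cytotoxicity, read by MTT assay, with a stated time of 72 h; a higher number here means a weaker inhibitor, a lower number a stronger inhibitor:
- compound 1 `Cn1nc(-c2nnc(-c3ccccc3Cl)o2)c2ccccc21` gives > 100000 nM, a limit of the assay and not a number.
- compound 2 `Cn1nc(-c2nnc(-c3ccccc3Br)o2)c2ccccc21` gives 89000 nM.

Compound 2 holds the only number shown; the other value is a limit (the limit of > 100000 nM in this assay, at which 1 of the 2 values shown sits). Among the measured compounds shown here, the one measured step is an at least 1.1-fold lower number from compound 1 to compound 2 (0.05 log units; that floor lies within the scatter), which lies within the scatter. Compound 3 `Cc1ccc(-c2nnc(-c3nn(C)c4ccccc34)o2)cc1` differs from compound 2 by 4-methylphenyl in place of 2-bromophenyl on an aromatic carbon. For the measured compounds named here, no measured step bears directly on a change of this kind; the single step on record swaps one halogen for another on the same ring and offers no guidance for a 4-methylphenyl in place of 2-bromophenyl. Given where compound 2 stands, no step beyond the scatter is expected in this assay in either direction. Compound 3 is expected at 95000 nM, between 45000 nM and 200000 nM. The implied step a 1.1-fold higher number from compound 2 to compound 3 (0.03 log units; within the scatter) is expected to stay within the scatter. A limit rather than a number is a fair possibility for compound 3.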

Compound 3, half-maximal inhibitory concentration: > 100000 nM
Compound 3 was reported as a limit; the forecaster's own chance of this, stated with the estimate: 50%; middle value at least 1.0-fold (0.02 log units) from the limit.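

In this assay, 4-methylphenyl in place of 2-bromophenyl on this aromatic carbon gives an at least 1.1-fold higher number from compound 2 to compound 3 (0.05 log units; that floor lies within the scatter), the first change shown that replaces the halogen-bearing phenyl rather than swapping one halogen for another. Compound 3 gives > 100000 nM, a limit of the assay and not a number. A phenyl group carrying no halogen at this position therefore also yields no reading below the limit, which now holds most of the series: the limit of > 100000 nM in this assay, at which 2 of the 3 values shown sit.

The step between compound 1 and compound 3 cannot be read, as both values are limits, so 4-methylphenyl and 2-chlorophenyl cannot be ordered. As far as these compounds go, whether an amine or a carboxylic acid on this phenyl ring would bring a number clearly below the limit in this assay remains open.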